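A few compounds are considered here, and "the series" means these few. Any claim that something is new, unique, unknown or untested is made for them only; others in the source may bear on it.

Measured compounds:
- compound 1, `O=C1O/C(=C\Cn2cc(-c3ccc(Br)cc3)nn2)C(OCc2ccccc2)=C1OCc1ccccc1`; in a functional assay on CFPAC-1 cells (Homo sapiens) for antiproliferative activity, read by MTT assay, with a stated time of 72 h (a higher number here means a weaker inhibitor, a lower number a stronger inhibitor), compound 1 gives > 100000 nM
- compound 2, `O=C1O/C(=C\Cn2cc(-c3cc(F)cc(F)c3)nn2)C(OCc2ccccc2)=C1OCc1ccccc1`; in this assay compound 2 gives "not active" (no number reported)

Both entries in this assay are non-values. The result for compound 1 is a limit of the assay, not a number. For compound 2 no number is given at all, only the word that it was not active, so compound 2 cannot be placed on a scale against compound 1 beyond the statement that neither shows measurable inhibition; the only other entry is the limit of > 100000 nM in this assay, at which 1 of the 2 values shown sits.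

Compound 3, `CCCCCc1ccc(-c2cn(C/C=C3\OC(=O)C(OCc4ccccc4)=C3OCc3ccccc3)nn2)cc1`, is the next compound and is not yet measured. It differs from compound 2 in one place: 4-pentylphenyl in place of 3,5-difluorophenyl on an aromatic carbon. Among the measured compounds shown here, with no measured step between any two compounds in this set, there is no basis for expecting a change in this assay beyond the scatter in either direction; the working expectation is that compound 3 also comes out weak or as a limit. Compound 3 is expected to give about 80000 nM in this assay, with a range from 15000 nM to 300000 nM.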

Compound 3, half-maximal inhibitory concentration: > 100000 nM
Compound 3: no number, only a limit; the forecaster's own chance of this, stated with the estimate: 65%; middle value at least 1.2-fold (0.09 log units) from the limit.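

In this assay compound 3 gives > 100000 nM, which is a limit of the assay and not a number. No step can be read between compound 3 and either compound 1 or compound 2, as none of the three has a number. The compounds shown leave open whether any group at this place on the shared core gives measurable inhibition.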